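From a Hexyl Chain Back to a Dimethoxyphenyl Ring

The compounds below may be only part of what the source reports. "The series", "measured", "known", "first", "only" and "open" are said of these compounds alone.

Three compounds share one core and differ only at a double-bonded chain carbon bound to a double-bonded ring carbon. Compound 1 `COc1ccc(/C=C2\S/C(=N\c3csc(-c4ccc(Cl)cc4)c3)NC2=O)cc1` carries a 4-methoxyphenyl group there and gives 3800 nM in a functional assay on HT-29 cells (Homo sapiens) for cytotoxicity, read by MTT assay, with a stated time of 72 h; on this read-out lower numbers stand for stronger inhibition and higher numbers for weaker inhibition. Compound 2 `Cc1ccc(/C=C2\S/C(=N\c3csc(-c4ccc(Cl)cc4)c3)NC2=O)cc1` carries a 4-methylphenyl group and gives 6400 nM in this assay; a 1.7-fold higher number from compound 1 to compound 2 (0.23 log units; within the scatter). Compound 3 `CCCCCC/C=C1\S/C(=N\c2csc(-c3ccc(Cl)cc3)c2)NC1=O` carries a hexyl chain and gives 33500 nM in this assay, the highest number of the three: an 8.8-fold higher number from compound 1 to compound 3 (0.95 log units; beyond the scatter), and a 5.2-fold higher number from compound 2 to compound 3 (0.72 log units; beyond the scatter).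

Compound 4 `COc1ccc(/C=C2\S/C(=N\c3csc(-c4ccc(Cl)cc4)c3)NC2=O)cc1OC` has not yet been measured. It differs from compound 3 as follows: 3,4-dimethoxyphenyl in place of hexyl on a double-bonded chain carbon bound to a double-bonded ring carbon. Both measured steps that bear on this change run in the opposite direction, from an aryl group to hexyl, and both raise the number by a modest but clear amount. Reversing that change is therefore expected to lower the number beyond the scatter, on the order of an 8.4-fold lower number from compound 3 to compound 4 (0.92 log units; beyond the scatter). Compound 4 is accordingly estimated at 4000 nM in this assay, with a range from 1500 nM to 12000 nM. Among the compounds with values here, no measured pair shows what a second methoxy group does, so that part of the change rests on the aryl-versus-hexyl steps alone.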

Compound 4, half-maximal inhibitory concentration: 10900 nM
Estimate against measurement, compound 4: 2.7-fold (0.44 log units) below; the range from low to high includes it.
By their numbers in this assay, from the lowest: compounds 1, 2 and 4 (each within the scatter of the next, the first and the last beyond it); then compound 3.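

Going back from the hexyl chain to an aryl group at this position again lowers the number in this assay (a 3.1-fold lower number from compound 3 to compound 4 (0.49 log units; beyond the scatter)), and compound 3 now stands beyond the scatter from all three aryl compounds, including one with a second methoxy group. Within the data shown here, the same result gives the first measured change on the aromatic ring that clears the scatter: adding the second methoxy group raises the number (a 2.9-fold higher number from compound 1 to compound 4 (0.46 log units; beyond the scatter)), whereas the earlier exchange of methoxy for methyl did not clear it. Compound 4 nevertheless cannot be separated from the methyl-bearing compound 2 (a 1.7-fold higher number from compound 2 to compound 4 (0.23 log units; within the scatter)), so the added methoxy group counts against compound 4 only when set against compound 1, its closest relative.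

Nothing available here explains why the second methoxy group raises the number or why the hexyl chain gives the highest one. Going by these compounds, it remains open whether a hydroxy group or a fluorine on the aromatic ring, or a shorter chain in place of hexyl, would fall with the aryl compounds or with compound 3.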